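A few compounds are considered here, and "the series" means these few. Any claim that something is new, unique, unknown or untested is made for them only; others in the source may bear on it.

Compound 2 `Fc1ccc(Cc2ccc3c(NCCCNCc4ccco4)ccnc3c2)c(Cl)c1` gives 9.47 in a physicochemical assay for acid dissociation, level with compound 1 `COc1ccc(-c2ccc3c(NCCCNCc4ccco4)ccnc3c2)cc1`, which gives 9.47. For the measured compounds named here, the only measured step bearing on the position in question, no change at the digits printed from compound 1 to compound 2 (within the scatter), left the read-out unchanged within the scatter. Compound 3 `c1coc(CNCCCNc2ccnc3cc(-c4cccc5ccccc45)ccc23)c1` differs from compound 2 by naphthalen-1-yl in place of 2-chloro-4-fluorobenzyl on an aromatic carbon. Since swapping a 4-methoxyphenyl for a 2-chloro-4-fluorobenzyl at this aromatic carbon produced no shift, a further exchange there for naphthalen-1-yl is expected to give no step beyond the scatter, no change at the digits printed from compound 2 to compound 3 (within the scatter). Compound 3 is therefore estimated at 9.47, within 9.15 to 9.8.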

Compound 3, acid dissociation constant: 9.47
Estimate against measurement, compound 3: no gap at the digits printed; measured number inside the range.
By their numbers in this assay, from the lowest: compounds 1, 2 and 3 (each within the scatter of the next).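

In this assay, naphthalen-1-yl on this aromatic carbon gives no change at the digits printed from compound 2 to compound 3 (within the scatter) and, set against 4-methoxyphenyl, gives no change at the digits printed from compound 1 to compound 3 (within the scatter). The position has now carried three different groups, and a group with two six-membered aromatic rings of carbon only reads the same as 2-chloro-4-fluorobenzyl with its one such ring. Nothing available explains why the read-out holds level across these groups. On these data alone, whether an amine or a carboxylic acid on this carbon, or a change elsewhere on the shared core, would move the read-out remains open.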